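The source may hold more compounds than are shown below. What is called first, only, known or untested is meant among the compounds shown, and "the series" means these compounds.

Of the compounds shown here, two sharing one core have been measured in a functional assay for antagonist activity at transient receptor potential cation channel subfamily V member 1 (Homo sapiens), read by calcium flux; on this read-out higher numbers stand for weaker inhibition and lower numbers for stronger inhibition. Compound 1 `O=C(Nc1cccc2[nH]ncc12)N[C@@H]1CCOc2cc(C(F)(F)F)ccc21` gives 4 nM. Compound 2 `O=C(Nc1cccc2[nH]ncc12)NC1CCOc2c1cccc2C(F)(F)F` gives 5 nM in this assay; the two numbers lie within the scatter of each other, so on potency compound 2 cannot be set apart from compound 1. Compound 3 `O=C(Nc1cccc2[nH]ncc12)NC1CCOc2ccccc21` has not yet been measured. It differs from compound 2 in one place: hydrogen in place of trifluoromethyl on an aromatic carbon. Among the measured compounds shown here, no measured pair traces this particular change, so nothing measured tells how the number moves when the trifluoromethyl is taken away and only hydrogen remains on that aromatic carbon. Stripping a group of that kind from the ring is expected to cost some inhibition, so the estimated step is one toward a larger number, a 4.0-fold higher number from compound 2 to compound 3 (0.60 log units; beyond the scatter), somewhat beyond the scatter. For compound 3 in this assay the estimate is 20 nM, with a range from 5 nM to 80 nM.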

Compound 3, half-maximal inhibitory concentration: 234 nM
For compound 3 the middle estimate is 12-fold (1.07 log units) below the measured one; the measured number lies above the stated range.
By their numbers in this assay, from the lowest: compounds 1 and 2 (each within the scatter of the next); then compound 3.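

In this assay, taking the trifluoromethyl off this aromatic carbon, ortho to a fused ring and meta to a fused ring, and leaving only hydrogen gives a 47-fold higher number from compound 2 to compound 3 (1.67 log units; beyond the scatter). Much of the inhibition seen in compound 2 therefore depends on having the trifluoromethyl rather than hydrogen at this place, a dependence that the two earlier compounds could not reveal, since they offered no pair tracing this change. Nothing available accounts for the size of this loss.

As far as these compounds go, it remains open whether a smaller or different group on the same aromatic carbon, such as a chlorine atom, a methyl or a methoxy, would keep the number close to that of compound 2. Also open, from the compounds shown here alone, is whether removing the trifluoromethyl from its own place in compound 1 would cost as much.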